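One more chloro on the ring of compound 1

This account rests on a few compounds, and the source may have more. Where it says the series, first, only, none or still open, it means among the compounds named here.

compound 1 (`O=C(Nc1cc(Cl)cc(Cl)c1)c1cc(Cl)ccc1O`) gives 3100 nM
compound 2 (`CC(C)(C)c1cc(NC(=O)c2cc(Cl)ccc2O)cc(C(C)(C)C)c1`) gives 4100 nM

In an ADME assay on cells (Macrophage, Mus musculus) for cytotoxicity, read by resazurin assay, with a stated time of 3 days (a lower number here means a stronger inhibitor, a higher number a weaker inhibitor), compound 1 gives 3100 nM and compound 2 gives 4100 nM within the usual scatter of each other, so the two cannot be ranked. Compound 3 (`O=C(Nc1cc(Cl)c(Cl)c(Cl)c1)c1cc(Cl)ccc1O`) is compound 1 with chloro in place of hydrogen on an aromatic carbon, ortho to two chloro groups and para to a large group. Among the measured compounds shown here, no measured pair shows this change, so no step beyond the scatter is expected in this assay in either direction. The expected move is a 1.0-fold lower number from compound 1 to compound 3 (0.01 log units; within the scatter) and no more than that. For compound 3 the estimate is 3000 nM with an expected range from 1300 nM to 6500 nM when measured.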

Compound 3, half-maximal inhibitory concentration: 5400 nM
Compound 3: middle estimate off by 1.8-fold (0.26 log units), on the low side, and the stated range covers the measured number.
By their numbers in this assay, from the lowest: compounds 1, 2 and 3 (each within the scatter of the next).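

In this assay, adding a chloro ortho to two chloro groups and para to a large group gives a 1.7-fold higher number from compound 1 to compound 3 (0.24 log units; within the scatter). This first one-place pair therefore shows that this position accepts a third chloro on that ring without a step that can be told from the scatter. Nothing measured here speaks to what lies behind the numbers.

Still open, going by these compounds, is whether a different group at this position, such as an amine or a carboxylic acid, would give a step beyond the scatter.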